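The compounds below may be only part of what the source reports. "The series", "measured", "known", "first", "only" and "open" are said of these compounds alone.

Measured compounds in an assay on L1.2 cells for binding affinity to C-C chemokine receptor type 8 (Homo sapiens); a lower number here means a stronger inhibitor, a higher number a weaker inhibitor:
- compound 1 `Cc1ccccc1C(=O)Nc1ccc(S(=O)(=O)NC2CCN(C(=O)C3CCCC3)CC2)c2ccccc12`: 9.1 nM
- compound 2 `Cc1ccccc1C(=O)Nc1ccc(S(=O)(=O)NC2CCN(C(=O)CO)CC2)c2ccccc12`: 5.4 nM
- compound 3 `Cc1ccccc1C(=O)Nc1ccc(S(=O)(=O)NC2CCN(C(=O)CCN)CC2)c2ccccc12`: 11.3 nM

All three share one core and differ only in the group on the carbonyl carbon of the piperidine amide. Compound 3 carries the highest of the three numbers in this assay. Its nearest neighbour is compound 1, with a step of a 1.2-fold higher number from compound 1 to compound 3 (0.09 log units; within the scatter), so the two cannot be told apart. Compound 2 sits furthest away: the step of a 2.1-fold higher number from compound 2 to compound 3 (0.32 log units; beyond the scatter) is a modest one but does lie beyond the scatter, while a 1.7-fold lower number from compound 1 to compound 2 (0.23 log units; within the scatter) does not.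

Compound 4 `Cc1ccccc1C(=O)Nc1ccc(S(=O)(=O)NC2CCN(C(=O)C3CNC3)CC2)c2ccccc12` is the next member. The change from compound 3 is azetidin-3-yl in place of 2-aminoethyl on a carbonyl carbon. Within the data shown here, all three measured steps touch the same position on the carbonyl carbon and all are small; the widest spread is the one from compound 2 to compound 3. Among the measured compounds shown here, nothing among the measured pairs points to a large swing in either direction for this kind of exchange, so the expected step of a 1.3-fold lower number from compound 3 to compound 4 (0.10 log units; within the scatter) is one that stays within the scatter, perhaps edging toward a slightly lower number.

Compound 4 is therefore estimated at 9 nM in this assay, with a range from 4 nM to 25 nM.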

Compound 4, inhibition constant: 1.5 nM
Compound 4: middle estimate off by 6.0-fold (0.78 log units), on the high side; the whole stated range lies above it.
By their numbers in this assay, from the lowest: compound 4; then compounds 2, 1 and 3 (each within the scatter of the next, the first and the last beyond it).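

In this assay, among these compounds, the position on the carbonyl carbon proves more sensitive than the earlier compounds suggested: a 7.5-fold lower number from compound 3 to compound 4 (0.88 log units; beyond the scatter) is wider than any step among compounds 1, 2 and 3. The other two steps, a 3.6-fold lower number from compound 2 to compound 4 (0.56 log units; beyond the scatter) and a 6.1-fold lower number from compound 1 to compound 4 (0.78 log units; beyond the scatter), also lie beyond the scatter, which sets compound 4 apart as the strongest of the four in this series. Azetidin-3-yl and 2-aminoethyl have the same hydrogen-bond donor and acceptor counts and no net charge, so they differ in the four-membered ring and the added carbon, yet a ring alone does not give such a low number, as compound 1, with cyclopentyl, stands at 9.1 nM, and no measurement here explains the gain.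

The compounds shown leave open whether the gain needs both the ring nitrogen and the four-membered ring, a question that cyclobutyl on the same carbonyl carbon would address. They also leave open how much ring size matters while the nitrogen is kept, as pyrrolidin-3-yl or piperidin-4-yl would show.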